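The source may hold more compounds than are shown below. What is called first, only, known or untested is meant among the compounds shown, and "the series" means these compounds.

Measured in an assay on HEK293 cells for positive allosteric modulation of metabotropic glutamate receptor 2 (Rattus norvegicus), read by thallium flux, with a stated time of 2.5 min; a higher number here means that more compound is needed for the effect, a lower number that less compound is needed:
Compound 1 `Cc1c(OCCCCOc2ccc(C(=O)O)cc2F)ccc(C(=O)CC2CCCC2)c1O` gives 639 nM.
Compound 2 `CCC(=O)c1ccc(OCCCCOc2cc(C(=O)O)ccc2OC)c(C)c1O` gives 162 nM.
Compound 3 `COc1ccc(C(=O)O)cc1OCCCCOc1ccc(C(=O)C(C)C)c(O)c1C` gives 116 nM.

Compound 3 carries the lowest number of the three; compound 2 sits within the scatter of it, compound 1 beyond it. Among the compounds with values here, the only single-point step measured, a 1.4-fold lower number from compound 2 to compound 3 (0.15 log units; within the scatter), touched the ketone side and stayed within the scatter.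

Compound 4 `COc1ccc(C(=O)O)cc1OCCCCOc1ccc(C(=O)CC2CCCC2)c(O)c1C` differs from compound 3 by cyclopentylmethyl in place of isopropyl on a carbonyl carbon. Within the data shown here, no measured step covers this exact change. Compound 1 carries the same (cyclopentylmethyl)carbonyl but also a different acid-bearing ring, so its value speaks only loosely; it is higher than that of compound 3. A modest rise is expected, a 2.2-fold higher number from compound 3 to compound 4 (0.33 log units; beyond the scatter), possibly within scatter. Compound 4 is estimated at 250 nM, range 100 nM to 650 nM.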

Compound 4, half-maximal effective concentration: 425 nM
The estimate for compound 4 lay 1.7-fold (0.23 log units) below the measured number; low and high end bracket the measured number.
By their numbers in this assay, from the lowest: compounds 3 and 2 (each within the scatter of the next); then compounds 4 and 1 (each within the scatter of the next).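

With cyclopentylmethyl in place of isopropyl on the carbonyl carbon, the number rises beyond the scatter (a 3.7-fold higher number from compound 3 to compound 4 (0.56 log units; beyond the scatter)), so the group at this place does change the read-out. Cyclopentyl in place of methyl on the saturated chain carbon bound to the carbonyl carbon also gives a rise beyond the scatter (a 2.6-fold higher number from compound 2 to compound 4 (0.42 log units; beyond the scatter)), while 5-carboxy-2-methoxyphenyl in place of 4-carboxy-2-fluorophenyl stays within it (a 1.5-fold lower number from compound 1 to compound 4 (0.18 log units; within the scatter)). No evidence bearing on the reason for these differences accompanies the result.

Open, going by these compounds, is how a tert-butyl, an unbranched butyl chain or a phenyl ring on the carbonyl carbon would read, and thus whether the rise follows the ring or the added carbons.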